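Removing the alkenyl side chain from an inactive epoxyquinol core

The compounds below may be only part of what the source reports. "The series", "measured", "known", "first", "only" and "open" are said of these compounds alone.

The study centres on a small set of epoxyquinols tested in a functional assay on Jurkat cells (Homo sapiens); a higher number here means that more compound is needed for the effect, a lower number that less compound is needed. Compound 2, `C/C=C(\C)C1=C(CO)[C@H](O)[C@H]2O[C@H]2C1=O`, is the starting point of this step. In this assay compound 2 reaches only a limit of the assay, > 80 uM. Its relative compound 1, `C/C=C/C1=C(CO)[C@H](O)[C@H]2O[C@H]2C1=O`, likewise sits at a limit in this assay, > 80 uM. Compound 3, `C/C=C/C1=C(CO)[C@@H](O)[C@@H]2O[C@@H]2C1=O`, also gives only a limit in this assay, > 80 uM. Because of the limit of > 80 uM in this assay, at which 3 of the 3 values shown sit, neither a step that the two limits leave unreadable from compound 1 to compound 2 nor a step that the two limits leave unreadable from compound 1 to compound 3 can be read as a number, and the fact that compounds 1 and 3 differ only in the configuration as drawn adds that the last of these pairs differs only in configuration as drawn.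

Compound 4, `O=C1C=C(CO)[C@H](O)[C@H]2O[C@@H]12`, is the next compound, and its change from compound 2 is hydrogen in place of 1-methylprop-1-en-1-yl on a double-bonded ring carbon. No measured step speaks directly to the loss of this side chain, since every measured value is a limit, so no size or direction beyond the scatter can be anticipated; the shared core has so far shown no effect at the highest concentration tested. Compound 4 is therefore expected to behave like its neighbours, with an estimated value of 100 uM ranging from 40 uM to 300 uM, which means an expected step that the limit leaves unreadable from compound 2 to compound 4 that is most likely to be reported again as a limit.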

Compound 4, concentration for half-maximal effect: > 80 uM
Compound 4: only a limit was reported (the forecaster's own chance of this, stated with the estimate: 85%); the middle value does not contradict the limit.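

In this assay compound 4 gives > 80 uM, which is a limit of the assay. The steps from compound 2 and compound 1 to compound 4 therefore cannot be read as numbers, because no compound here has a measured value: the limit of > 80 uM in this assay, at which 4 of the 4 values shown sit.

The compounds shown leave open whether the side chain or the configuration of the shared core has any effect on the read-out.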